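The source may report more compounds than this note shows. Statements on the series, on what has been measured and on what is new or still open speak of the compounds shown alone.

Three sugar-bearing ketones have been tested in an assay for inhibition of glucose-6-phosphatase catalytic subunit 1 (Rattus norvegicus), tested at 100 uM; a higher number here means more inhibition at the concentration tested (going by the name of the read-out), a lower number less inhibition. Compound 1, `O=C(/C=C/c1ccc(Cl)cc1)C[C@@H]1OC[C@@H](O)[C@H](O)[C@H]1O`, gives 4.7%. Compound 2, `O=C(/C=C/c1ccc2ccccc2c1)C[C@@H]1O[C@H](CO)[C@@H](O)[C@H](O)[C@H]1O`, gives -7.7%. Compound 3, `CCOC(=O)C(C(=O)OCC)C(CC(=O)C[C@@H]1O[C@H](CO)[C@@H](O)[C@H](O)[C@H]1O)c1ccccc1`, gives -3.3%; its number is the second highest of the three, with compound 2 nearest and compound 1 furthest, and both of those gaps fall within the usual scatter of repeated measurements, so none of the three can be set apart from the others.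

Compound 4, `CCOC(=O)C(C(=O)OCC)C(CC(=O)C[C@@H]1O[C@H](CO)[C@@H](O)[C@H](O)[C@H]1O)c1ccc2ccccc2c1`, has not been measured in this assay. It differs from compound 3 in one place: naphthalen-2-yl in place of phenyl on a saturated chain carbon bound to two saturated chain carbons. Within the data shown here, no step between two measured compounds that differ in just one place is available, and compound 1 and compound 2, which carry different aromatic groups, also differ elsewhere, so only their two values can be compared, and those lie close together.

On this basis compound 4 is expected to show a step of a number 1.3 percentage points higher from compound 3 to compound 4 (within the scatter), that is, nothing beyond the scatter. The estimate for compound 4 is -2%, with a range from -15% to 12%.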

Compound 4, a percentage reported as inhibition, at one concentration (the size of the read-out at that concentration, not a potency): 4.6%
Estimate against measurement, compound 4: 6.6 percentage points below; the range from low to high includes it.
By their numbers in this assay, from the lowest: compounds 2, 3, 4 and 1 (each within the scatter of the next, the first and the last beyond it).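

Among these compounds, this is the first step at this position, on a saturated chain carbon bound to two saturated chain carbons, and it is one that can be read directly: in this assay, naphthalen-2-yl in place of phenyl gives a number 7.9 percentage points higher from compound 3 to compound 4 (within the scatter). Compound 3 and compound 4 therefore cannot be told apart, and the second six-membered aromatic ring of carbon only leaves no mark beyond the scatter at the single concentration tested. Among the compounds shown here, no evidence accompanies this step that could bear on its interpretation.

Still open, going by these compounds, is how a pyridine ring, an aromatic ring bearing an amine, or a plain methyl group at this position would read in this assay. Also open, on these data alone, is whether free carboxylic acids in place of the two ethyl esters would take the number beyond the scatter.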